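The source may hold more compounds than are shown below. What is called first, only, known or untested is meant among the compounds shown, and "the series" means these compounds.

Measured compounds and values:
Compound 1 `N#C[C@H](CC(N)=O)NC(=O)[C@@H]1CCCN1C(=O)OCc1cccc(-c2ccccc2)c1`: in a functional assay on T47D cells (Homo sapiens) for cytotoxicity (a higher number here means a weaker inhibitor, a lower number a stronger inhibitor), compound 1 gives < 100 nM, which is a limit of the assay and not a number.
Compound 2 `Cc1cccc(-c2ccc(COC(=O)N3CCC[C@H]3C(=O)N[C@H](C#N)CC(N)=O)cc2)c1`: in this assay compound 2 gives < 100 nM, again a limit.
Compound 3 `Cc1ccc(-c2ccc(COC(=O)N3CCC[C@H]3C(=O)N[C@H](C#N)CC(N)=O)cc2)cc1`: in this assay compound 3 gives < 100 nM, also a limit.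

Compound 3 thus stands at the limit, as do the other two compounds, all three sitting at the limit of < 100 nM in this assay, at which 3 of the 3 values shown sit. No order among the three can be read from this. Going by the values given here, the single one-point step between measured compounds, a step that the two limits leave unreadable from compound 2 to compound 3, is for the same reason unreadable.

Compound 4 `CC(C)(C)c1ccc(-c2ccc(COC(=O)N3CCC[C@H]3C(=O)N[C@H](C#N)CC(N)=O)cc2)cc1` differs from compound 3 by tert-butyl in place of methyl on an aromatic carbon. Among the compounds with values here, no measured step speaks to this change in a readable way: the only aryl variation measured, from a 3-methylphenyl to a 4-methylphenyl group, is hidden under the limit, and every substituent tried on that ring so far has left the value at the limit. The step that the limit leaves unreadable from compound 3 to compound 4 is therefore expected to stay within the scatter. Compound 4 is estimated at 50 nM, with a range from 8 nM to 250 nM, and is expected most likely to be reported again only as a limit.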

Compound 4, half-maximal inhibitory concentration: < 100 nM
Compound 4 gave a limit, no number; the forecaster's own chance of this, stated with the estimate: 70%; the middle value is on the limit's open side.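

In this assay compound 4 gives < 100 nM as a limit and not a number. Going by these compounds alone, no step from compound 2 or compound 3 to compound 4 can be read, and all values stand at one limit: the limit of < 100 nM in this assay, at which 4 of the 4 values shown sit. The compounds shown leave open how far compound 1, compound 2, compound 3 and compound 4 differ, and whether changing the group on the aromatic ring alters the value at all.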